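From Methyl to tert-Butyl on a Weakly Active Scaffold

The source may report more compounds than this note shows. Statements on the series, on what has been measured and on what is new or still open speak of the compounds shown alone.

Of the compounds shown here, three have been tested in a functional assay on HCT-116 cells (Homo sapiens) for antiproliferative activity, read by MTT assay, with a stated time of 24 h; on this read-out higher numbers stand for weaker inhibition and lower numbers for stronger inhibition. Compound 1 `O=C1O/C(=C\Cn2cc(-c3ccccc3)nn2)C(OCc2ccccc2)=C1OCc1ccccc1` reaches only the limit of the measurement, > 100000 nM. Compound 3 `CCCc1cn(CCC2(O)C(OCc3ccccc3)=C(OCc3ccccc3)C(=O)N2CCC)nn1` likewise gives only a limit, > 100000 nM. Within the data shown here, compound 2 `Cc1ccc(-c2cn(CCC3(O)NC(=O)C(OCc4ccccc4)=C3OCc3ccccc3)nn2)cc1` is the one compound with an actual number, 74300 nM. The remaining results thus sit at the limit of > 100000 nM in this assay, at which 2 of the 3 values shown sit. Compound 4 `CC(C)(C)c1ccc(-c2cn(CCC3(O)NC(=O)C(OCc4ccccc4)=C3OCc3ccccc3)nn2)cc1` has not yet been measured; it differs from compound 2 by tert-butyl in place of methyl on an aromatic carbon. Among the measured compounds shown here, no step between two measured compounds is available, so the effect of this change is unknown. A change no larger than the usual scatter, in either direction, is expected, so the step of a 1.4-fold lower number from compound 2 to compound 4 (0.13 log units; within the scatter) is estimated to be small. Compound 4 is therefore expected to give about 55000 nM in this assay, within 15000 nM to 150000 nM.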

Compound 4, half-maximal inhibitory concentration: > 100000 nM
Compound 4: only a limit was reported; the forecaster's own chance of this, stated with the estimate: 35%; middle value at least 1.8-fold (0.25 log units) from the limit.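

Replacing methyl with tert-butyl on this aromatic carbon gives an at least 1.3-fold higher number from compound 2 to compound 4 (0.12 log units; that floor lies within the scatter) in this assay. Compound 4 gives only a limit, so this step is a floor, and that floor does not clear the usual scatter. Even so, tert-butyl here brings no sign of stronger inhibition, and the set now gathers at one end of the range: the limit of > 100000 nM in this assay, at which 3 of the 4 values shown sit.

From the compounds shown here alone, whether an amine or a carboxylic acid in this place would give a lower number remains open. Going by these compounds, the true size of the step also remains open, since a limit cannot supply it.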